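The source may report more compounds than this note shows. Statements on the series, on what has been measured and on what is new or still open speak of the compounds shown alone.

Compound 1 `Cc1cc(NC(=O)Nc2ccc(F)cc2)c2ccccc2n1`: > 25000 nM (a limit)
Compound 2 `COC(=O)c1ccc(NC(=O)Nc2cc(C)nc3ccccc23)cc1`: 21000 nM

For the measured compounds named here, in an ADME assay on BJ cells (Homo sapiens) for cytotoxicity, with a stated time of 72 h (a lower number here means that less compound is needed, a higher number that more compound is needed for the effect), compound 2 gives the only actual number so far, 21000 nM. Compound 1 rests at the limit of > 25000 nM in this assay, at which 1 of the 2 values shown sits.

Compound 3 `Cc1cc(NC(=O)Nc2ccc(C(N)=O)cc2)c2ccccc2n1` differs from compound 2 by amino in place of methoxy on a carbonyl carbon, or methoxycarbonyl to carbamoyl.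

Going by the values given here, the one measured step that bears on this change, at the same group, is an at least 1.1-fold lower number from compound 1 to compound 2 (0.07 log units; that floor lies within the scatter). On that small step, no change beyond the scatter is expected in this assay, and a reading at the limit is possible. The expected step is a 1.1-fold higher number from compound 2 to compound 3 (0.04 log units; within the scatter). For compound 3 the estimate is 23000 nM, with an estimated range of 12000 nM to 35000 nM.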

Compound 3, half-maximal effective concentration: > 25000 nM
Compound 3 gave a limit, no number (the forecaster's own chance of this, stated with the estimate: 50%); middle value at least 1.0-fold (0.03 log units) away from the limit.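

In this assay, amino in place of methoxy on a carbonyl carbon gives an at least 1.1-fold higher number from compound 2 to compound 3 (0.07 log units; that floor lies within the scatter), so the change from methoxycarbonyl to carbamoyl shows no shift beyond the scatter. Compound 3 is a limit and not a number, and it adds to the values resting there: the limit of > 25000 nM in this assay, at which 2 of the 3 values shown sit. The step between the fluoro and carbamoyl compounds cannot be read, as both values are limits.

From the compounds shown here alone, whether any change at this group moves the value beyond the scatter remains open. A carboxylic acid or a longer ester chain in place of the methoxycarbonyl would test this in this assay.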